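The source may report more compounds than this note shows. Statements on the series, on what has been measured and on what is new or still open speak of the compounds shown alone.

Measured in a functional assay on DU-145 cells (Homo sapiens) for cytotoxicity, read by MTT assay, with a stated time of 48 h; on this read-out lower numbers stand for stronger inhibition and higher numbers for weaker inhibition:
- compound 1 `COc1ccc(-c2nc3ccccn3c2C(=O)/C=C\Nc2cnc3ccccc3c2)cc1`: 5280 nM
- compound 2 `COc1ccc(-c2nc3ccccn3c2C(=O)/C=C\Nc2ccc3ncccc3c2)cc1`: 4720 nM
- compound 3 `O=C(/C=C\Nc1cnc2ccccc2c1)c1c(-c2ccccc2)nc2ccccn12`: 2440 nM

Compound 2, at 4720 nM, lies within the scatter of both other compounds. Compound 4 `O=C(/C=C\Nc1ccc2ncccc2c1)c1c(-c2ccc(Cl)cc2)nc2ccccn12` differs from it by one change, 4-methoxyphenyl to 4-chlorophenyl: chloro in place of methoxy on an aromatic carbon. Among the compounds with values here, no measured compound carries chloro, so the evidence is indirect. The closest guide is a 2.2-fold lower number from compound 1 to compound 3 (0.34 log units; beyond the scatter), where hydrogen took the place of the same methoxy. The other step, a 1.1-fold lower number from compound 1 to compound 2 (0.05 log units; within the scatter), suggests that the quinolin-6-yl group of compound 2 need not alter this picture. A small drop is therefore expected, perhaps none beyond the scatter. The estimate means an expected 1.6-fold lower number from compound 2 to compound 4 (0.20 log units; within the scatter). Compound 4 is expected near 3000 nM, with an estimated range of 1300 nM to 7000 nM.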

Compound 4, half-maximal inhibitory concentration: 13600 nM
Compound 4: middle estimate off by 4.5-fold (0.66 log units), on the low side; the measured number lies above the stated range.
By their numbers in this assay, from the lowest: compounds 3, 2 and 1 (each within the scatter of the next, the first and the last beyond it); then compound 4.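

In this assay, this position responds in both directions: chloro in place of methoxy gives a 2.9-fold higher number from compound 2 to compound 4 (0.46 log units; beyond the scatter), while hydrogen in place of methoxy gave a 2.2-fold lower number from compound 1 to compound 3 (0.34 log units; beyond the scatter). The earlier step therefore does not carry over to every replacement of methoxy, and the group that enters matters, not only the loss of methoxy. Nothing available explains the difference between chloro and hydrogen. Still open, going by these compounds, is whether chloro would give a similar step alongside the quinolin-3-yl group. Also open, on these data alone, is how an amine or a carboxylic acid at this position would compare.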